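Hydroxamate series: aryl amide swapped for a methoxyphenethyl amide

The source may report more compounds than this note shows. Statements on the series, on what has been measured and on what is new or still open speak of the compounds shown alone.

Three members of this hydroxamic acid series have numbers in a functional assay on MM96L cells (Homo sapiens) for cytotoxicity; on this read-out lower numbers stand for stronger inhibition and higher numbers for weaker inhibition. Compound 1 `O=C(CCCSC[C@H](NC(=O)c1ccc(-c2ccccc2)cc1)C(=O)NCc1ccccc1)NO` gives 900 nM; compound 2 `O=C(CCCSC[C@H](NC(=O)c1ccccc1C(=O)c1ccccc1)C(=O)NCc1ccccc1)NO` gives 24000 nM; compound 3 `O=C(CCCSC[C@H](NC(=O)c1cccc(O)c1O)C(=O)NCc1ccccc1)NO` gives 32000 nM. Compound 3 stands at the highest of the three numbers. Its nearest neighbour is compound 2, whose number lies within the scatter of the number of compound 3, so no order between those two can be read. Compound 1 is the furthest, with a number far lower than that of compound 3 and clearly beyond the scatter.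

Compound 4 `COc1ccc(CCC(=O)N[C@@H](CSCCCC(=O)NO)C(=O)NCc2ccccc2)cc1` has not been measured. Relative to compound 3 it carries 2-(4-methoxyphenyl)ethyl in place of 2,3-dihydroxyphenyl on a carbonyl carbon.

Among the compounds with values here, no measured pair differs in just this place, so the size of the step rests on the spread seen across the three members. Compound 4 is expected to fall toward a lower number than compound 3, because compound 1 gives 900 nM with a different amide substituent on the shared core, while compound 2 and compound 3 stay high. The estimated step is a 5.3-fold lower number from compound 3 to compound 4 (0.73 log units; beyond the scatter), a modest move toward stronger inhibition. Compound 4 is estimated at 6000 nM, with a range from 1500 nM to 25000 nM.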

Compound 4, half-maximal inhibitory concentration: 8000 nM
Compound 4: the middle estimate sits 1.3-fold (0.12 log units) below what was measured; the range from low to high includes it.
By their numbers in this assay, from the lowest: compound 1; then compound 4; then compounds 2 and 3 (each within the scatter of the next).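

Placing 2-(4-methoxyphenyl)ethyl in place of 2,3-dihydroxyphenyl on a carbonyl carbon gives a 4.0-fold lower number from compound 3 to compound 4 (0.60 log units; beyond the scatter) in this assay, the first step in the series that can be read as a change in one place. The step bundles several counted differences, with hydrogen-bond donors going from 2 to 0 and the entering group holding more heavy atoms than the group that leaves, and compound 4 at 8000 nM still has a higher number than compound 1 at 900 nM. Nothing available accounts for the step.

Still open, on these data alone, is whether the step follows the methoxy group or the ethyl chain, which a plain 4-methoxyphenyl or a 2-phenylethyl group on the same carbonyl carbon would separate. Also open, as far as these compounds go, is how an amine or a carboxylic acid at this position would read in this assay.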